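A few compounds are considered here, and "the series" means these few. Any claim that something is new, unique, unknown or untested is made for them only; others in the source may bear on it.

Measured so far in a functional assay on the whole organism (stomach) with Rattus norvegicus as the target; a lower number here means that less compound is needed, a higher number that more compound is needed for the effect:
compound 1 `N=C(S)CCn1nc(-c2ccc(Cl)c(Cl)c2)ccc1=O`, compound 1 gives 78.1 mg/kg.
compound 2 `N=C(S)CCn1nc(-c2ccc(Cl)cc2)ccc1=O`; compound 2 gives only a limit, > 100 mg/kg.
compound 3 `N=C(S)CCN1N=C(c2ccccc2)CCC1=O`; compound 3 likewise gives only a limit, > 100 mg/kg.

The difference between the cores of compound 2 and compound 3 is not broken down here. From compound 2 to compound 1 the change is chloro in place of hydrogen on an aromatic carbon, and this assay shows an at least 1.2-fold lower number from compound 2 to compound 1 (0.10 log units; that floor lies within the scatter). Compound 4 `N=C(S)CCN1N=C(c2ccc(Cl)cc2)CCC1=O` is not yet measured; from compound 3 it differs by chloro in place of hydrogen on an aromatic carbon. Around the place the surroundings differ, ortho to a chloro group and meta to a large group in one case, para to a large group in the other, so it is the same kind of change, not the same. The step expected is a step that the limit leaves unreadable from compound 3 to compound 4, resting on the small measured step and on (the limit of > 100 mg/kg in this assay, at which 2 of the 3 values shown sit). For compound 4 the estimate is 150 mg/kg, from 70 mg/kg to 400 mg/kg.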

Compound 4, dose for half-maximal effect: > 100 mg/kg
Compound 4 ended at the assay's limit; the forecaster's own chance of this, stated with the estimate: 70%; the middle value lies beyond the limit too.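

Compound 3 and compound 4 both end at the limit of this assay, and no step can be read between them. The compounds shown leave open what chloro in place of hydrogen on an aromatic carbon does on the core of compound 3.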